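From butoxy to methylamino on compound 1

This account rests on a few compounds, and the source may have more. Where it says the series, first, only, none or still open, it means among the compounds named here.

Among the compounds with values here, in a physicochemical assay for lipophilicity, in phosphate buffer, measured as octanol-water partition, at pH 11.5 (on this read-out lower numbers stand for lower lipophilicity and higher numbers for higher lipophilicity), compound 1 `CCCCOC(=N)NC(=N)Nc1ccc(Cl)cc1` gives 3.32, the lower of the two numbers so far, while compound 2 `CCCCCCOC(=N)NC(=N)Nc1ccc(Cl)cc1` gives 4.32. Unmeasured compound 3 `CNC(=N)NC(=N)Nc1ccc(Cl)cc1` differs from compound 1 by methylamino in place of butoxy on a carbon with a double bond to nitrogen, with methylamino in place of butoxy. Within the data shown here, the only measured step, a number 1.00 log units higher from compound 1 to compound 2 (beyond the scatter), came with a longer chain and is modest. Among the measured compounds shown here, no measured step covers this exchange itself, but methylamino is the smaller group, so a downward step larger than that one is expected. The expected step is a number 1.82 log units lower from compound 1 to compound 3 (beyond the scatter). For compound 3 the estimate is 1.5, with an expected range of 0.8 to 2.2.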

Compound 3, partition coefficient: 1.58
For compound 3 the middle estimate is 0.08 log units below the measured one; measured number inside the range.
By their numbers in this assay, from the lowest: compound 3; then compound 1; then compound 2.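

In this assay, the exchange on a carbon with a double bond to nitrogen gives a number 1.74 log units lower from compound 1 to compound 3 (beyond the scatter) and leaves compound 3 as the lowest of the three compounds. This single change alters two things at once: the group goes from 5 heavy atoms to 2, and an oxygen-linked chain gives way to a nitrogen-linked group with 1 hydrogen-bond donor. No measurement shown here explains the size of this step.

As far as these compounds go, how much of the step belongs to the shorter chain and how much to the change from oxygen to nitrogen stays open. Butylamino or methoxy at this place would be needed to separate the two.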